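The compounds below may be only part of what the source reports. "The series", "measured", "known", "first", "only" and "open" are said of these compounds alone.

Measured so far in a functional assay on the whole organism for inhibition, with Lepidium sativum as the target, tested at 1 ppm; a lower number here means less inhibition of growth, a higher number more inhibition of growth at the concentration tested:
Compound 1, `CCCOC(=O)C(C)ON1C(=O)c2ccccc2C1=O`, gives 64%.
Compound 2, `CCCCCOC(=O)C(C)ON1C(=O)c2ccccc2C1=O`, gives 64%.

Compound 2 stands level with compound 1; the two readings lie within the scatter of each other. Going by the values given here, the only step measured so far, no change at the digits printed from compound 1 to compound 2 (within the scatter), puts ethyl in place of hydrogen on a saturated chain carbon, three bonds along the chain from an oxygen next to a carbonyl group, and growth inhibition did not move with it.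

Compound 3, `CCCCOC(=O)C(C)ON1C(=O)c2ccccc2C1=O`, is the next member. It differs from compound 2 by hydrogen in place of methyl on a saturated chain carbon, four bonds along the chain from an oxygen next to a carbonyl group, so the chain becomes shorter rather than longer, but along the same stretch of chain that the measured step altered. Because the step of no change at the digits printed from compound 1 to compound 2 (within the scatter) stayed flat when that chain was lengthened, trimming it is expected to change nothing beyond the scatter either, and the step of no change at the digits printed from compound 2 to compound 3 (within the scatter) is the estimate. Compound 3 is therefore expected to give 64%, within 52% to 76%.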

Compound 3, percent growth inhibition at one concentration: 59%
Compound 3: the middle estimate sits 5 percentage points above what was measured; measured number inside the range.
By their numbers in this assay, from the lowest: compounds 3, 1 and 2 (each within the scatter of the next).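

In this assay the chain now has a third length, and the readings show a number 5 percentage points lower from compound 2 to compound 3 (within the scatter) and also a number 5 percentage points lower from compound 1 to compound 3 (within the scatter) so the compound with the middle length does not separate from either neighbour. Hydrogen in place of methyl on a saturated chain carbon, four bonds along the chain from an oxygen next to a carbonyl group, is thus a second change along this stretch of chain that stays inside the scatter, and across these three compounds chain length gives no readable difference in growth inhibition. No independent evidence bears on this result.

Still open, going by these compounds, is whether a much longer chain, such as decyl, or a chain ending in an amine or a carboxylic acid, would shift the reading. On these data alone, whether the same flat picture holds at other concentrations is also open.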